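The compounds below may be only part of what the source reports. "The series", "measured", "known", "first", "only" and "open" are said of these compounds alone.

Measured compounds:
compound 1 `O=[N+]([O-])c1cccc(Nc2nc(SCc3ccc(C(F)(F)F)cc3)nc3ccccc23)c1`; in a functional assay on MGC-803 cells (Homo sapiens) for cytotoxicity, read by MTT assay, with a stated time of 72 h (a lower number here means a stronger inhibitor, a higher number a weaker inhibitor), compound 1 gives > 50000 nM, which is a limit of the assay and not a number.
compound 2 `COc1ccc(Nc2nc(SCc3ccc(C(F)(F)F)cc3)nc3ccccc23)c(OC)c1`; in this assay compound 2 gives > 50000 nM, again a limit and not a number.

Compound 2 thus stands only at a limit in this assay; both values shown sit at the same limit (the limit of > 50000 nM in this assay, at which 2 of the 2 values shown sit), so no ordering between the two compounds can be read. Among the compounds with values here, the single measured step, a step that the two limits leave unreadable from compound 1 to compound 2, is left unreadable by the two limits and gives no direction for the size of any further change on this nitrogen.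

The change to compound 3 `COc1cc(Nc2nc(SCc3ccc(C(F)(F)F)cc3)nc3ccccc23)cc(OC)c1` is 3,5-dimethoxyphenyl in place of 2,4-dimethoxyphenyl on a nitrogen on an aromatic ring. Within the data shown here, the same atoms are kept and only rearranged on the phenyl ring; no measured step bears on this rearrangement beyond the unreadable one just named. Compound 3 is therefore expected to remain at the same limit, with a step that the limit leaves unreadable from compound 2 to compound 3 expected to be no step beyond the scatter. Compound 3 is estimated at 70000 nM, with a range from 20000 nM to 250000 nM, and most probably it will again be reported only as a limit.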

Compound 3, half-maximal inhibitory concentration: 8580 nM
Compound 3: middle estimate off by 8.2-fold (0.91 log units), on the high side; the measured number lies below the stated range.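

In this assay, the substituted phenyl on this nitrogen can yield a readable number, and the arrangement of the two methoxy groups alone is enough to change the result: the same atoms give an at least 5.8-fold lower number from compound 2 to compound 3 (0.76 log units; beyond the scatter). Replacing 3-nitrophenyl with 3,5-dimethoxyphenyl gives an at least 5.8-fold lower number from compound 1 to compound 3 (0.76 log units; beyond the scatter), so among these three compounds only the 3,5-dimethoxyphenyl group gives a value that is not a limit. Compound 1 and compound 2 each remain at a limit and not a number, so both steps give only a minimum size: the limit of > 50000 nM in this assay, at which 2 of the 3 values shown sit.

On these data alone, it remains open whether both methoxy groups are needed or whether a single methoxy group would give a readable number. Also open, as far as these compounds go, is how ethoxy, hydroxyl or amine groups would fare in their place on this phenyl ring.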